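Amide aryl swap at the carbonyl: notes toward compound 4

The compounds below may be only part of what the source reports. "The series", "measured", "known", "first", "only" and "open" are said of these compounds alone.

Measured so far in a functional assay on HepG2 cells (Homo sapiens) for antiproliferative activity, read by MTT assay, with a stated time of 24 h; a lower number here means a stronger inhibitor, a higher number a weaker inhibitor:
compound 1 `COC(=O)c1scc(-c2ccc(NC(=O)c3ccc(OC)nc3)cc2)c1OC`: > 50000 nM
compound 2 `COC(=O)c1scc(-c2ccc(NC(=O)c3ccc(C#N)nc3)cc2)c1OC`: 22500 nM
compound 3 `COC(=O)c1scc(-c2ccc(NC(=O)c3cccc(C(F)(F)F)c3)cc2)c1OC`: 32500 nM

The value of compound 1 is a limit of this assay, (the limit of > 50000 nM in this assay, at which 1 of the 3 values shown sits). Compound 2 and compound 3 give numbers, and compound 3 stands highest of those two, although the step of a 1.4-fold higher number from compound 2 to compound 3 (0.16 log units; within the scatter) lies within the scatter. Against the limit, the step of an at least 1.5-fold lower number from compound 1 to compound 3 (0.18 log units; that floor lies within the scatter) is also not secure, whereas an at least 2.2-fold lower number from compound 1 to compound 2 (0.34 log units; beyond the scatter) is at least modest.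

The next compound, compound 4 `COC(=O)c1scc(-c2ccc(NC(=O)c3ccc(F)c(Cl)n3)cc2)c1OC`, differs from compound 3 only at the aryl of the amide: 6-chloro-5-fluoropyridin-2-yl in place of 3-(trifluoromethyl)phenyl on a carbonyl carbon. For the measured compounds named here, the steps that bear on this are the two other aryl swaps on the same carbonyl carbon, an at least 1.5-fold lower number from compound 1 to compound 3 (0.18 log units; that floor lies within the scatter) and a 1.4-fold higher number from compound 2 to compound 3 (0.16 log units; within the scatter), both small and both among weak inhibitors, while an at least 2.2-fold lower number from compound 1 to compound 2 (0.34 log units; beyond the scatter) shows that a substituent change within the pyridine can reach a modest step. None of these gives ground for a step beyond the scatter in either direction for compound 4.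

For compound 4 in this assay the expected value is 30000 nM, with a range of 12000 nM to 80000 nM. This estimate means a step of a 1.1-fold lower number from compound 3 to compound 4 (0.03 log units; within the scatter), which is expected to stay within the scatter.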

Compound 4, half-maximal inhibitory concentration: 10300 nM
Compound 4: the middle estimate sits 2.9-fold (0.46 log units) above what was measured, outside the stated range (below it).
By their numbers in this assay, from the lowest: compound 4; then compounds 2 and 3 (each within the scatter of the next). At a limit, above all of these: compound 1.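

In this assay, the aryl on the carbonyl carbon can now be seen to move the number beyond the scatter in swaps between measured compounds: a 3.2-fold lower number from compound 3 to compound 4 (0.50 log units; beyond the scatter) and a 2.2-fold lower number from compound 2 to compound 4 (0.34 log units; beyond the scatter), whereas a 1.4-fold higher number from compound 2 to compound 3 (0.16 log units; within the scatter) gave no readable difference. With 6-chloro-5-fluoropyridin-2-yl on that carbon, compound 4 holds the lowest number of the series, and an at least 4.8-fold lower number from compound 1 to compound 4 (0.68 log units; beyond the scatter) extends the earlier pattern, though that step gives only a floor and the real gap could be larger. The value of compound 1 is a limit and not a number: the limit of > 50000 nM in this assay, at which 1 of the 4 values shown sits.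

The swap from 3-(trifluoromethyl)phenyl changes the ring nitrogen, the chlorine and the fluorine together, so the compounds shown cannot assign the lower number to any one of them, and compound 4 differs from compound 2 in more than a single substituent. Going by these compounds, it also remains open whether an amine or a carboxylic acid on the same pyridine would keep the number low or lose the step, and whether any aryl at this place can bring the series far below the level of compound 4.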